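The source may hold more compounds than are shown below. What is called first, only, known or untested is meant among the compounds shown, and "the series" means these compounds.

Compounds measured so far:
- compound 1 `COc1ccc(CNc2nc([SeH])nc3ccccc23)cc1` — > 100000 nM (a limit)
- compound 2 `CSc1ccc(CNc2nc([SeH])nc3ccccc23)cc1` — > 100000 nM (a limit)
- compound 3 `[SeH]c1nc(NCc2ccccc2)c2ccccc2n1` — > 100000 nM (a limit)

In a functional assay on HT-29 cells (Homo sapiens) for cytotoxicity, read by MTT assay, with a stated time of 72 h (a higher number here means a weaker inhibitor of growth, a lower number a stronger inhibitor of growth), compound 1 gives only a limit, > 100000 nM. Compound 2 likewise gives only a limit, > 100000 nM. Compound 3 also gives only a limit, > 100000 nM. All three sit at the limit of > 100000 nM in this assay, at which 3 of the 3 values shown sit, so no value in the series is a number and compound 1 cannot be placed relative to the others. Among the compounds with values here, the steps a step that the two limits leave unreadable from compound 1 to compound 2, a step that the two limits leave unreadable from compound 1 to compound 3 and a step that the two limits leave unreadable from compound 2 to compound 3 are therefore not readable in size; what they show is only that changing the group on the benzyl ring has not brought any compound into the measurable range.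

Compound 4 `COc1ccc(CNc2nc(S)nc3ccccc23)cc1` differs from compound 1 by one sulfur atom in place of one selenium atom, on an aromatic carbon. Within the data shown here, no measured step bears on this exchange, and the shared core has not yet been varied at that carbon. With compound 1 at a limit, the step that the limit leaves unreadable from compound 1 to compound 4 expected from compound 1 to compound 4 cannot be read against a number, and the most likely outcome is again a limit. Compound 4 is estimated at 150000 nM in this assay, within 30000 nM to 1000000 nM.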

Compound 4, concentration for total growth inhibition: 28600 nM
For compound 4 the middle estimate is 5.2-fold (0.72 log units) above the measured one, outside the stated range (below it).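

In this assay, within the data shown here, the exchange at the carbon between two ring nitrogen atoms gives an at least 3.4-fold lower number from compound 1 to compound 4 (0.54 log units; beyond the scatter), the first change to bring a compound into the measurable range. The three selenium compounds differ only in the group on the benzyl ring and none gives a number, so this carbon is the one place shown where a change has a readable effect on growth inhibition. The size of the step remains a lower bound only, because compound 1 sits at a limit: the limit of > 100000 nM in this assay, at which 3 of the 4 values shown sit.

The compounds shown leave open whether sulfanyl at this carbon would also give numbers with the methylsulfanyl or unsubstituted benzyl groups of compound 2 and compound 3, and so whether the benzyl ring matters once selenium is gone. They also leave open how an amine or a methylsulfanyl group at this same carbon would compare with sulfanyl.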